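Benzyl for Propargyl on the Thioether of a Triazolopyrimidine Hydrazone

This account rests on a few compounds, and the source may have more. Where it says the series, first, only, none or still open, it means among the compounds named here.

Measured compounds:
compound 1, `C#CCSc1nc(N/N=C/c2cc(OC)c(OC)c(OC)c2)c2nnn(Cc3ccccc3)c2n1`, 25600 nM
compound 2, `CCCSc1nc(N/N=C(\C)c2ccccc2O)c2nnn(Cc3ccccc3)c2n1`, 32300 nM
compound 3, `CCCSc1nc(N/N=C/c2c(O)ccc3ccccc23)c2nnn(Cc3ccccc3)c2n1`, 13100 nM

In an ADME assay on GES1 cells (Homo sapiens) for antiproliferative activity, read by MTT assay, with a stated time of 72 h (on this read-out lower numbers stand for stronger inhibition and higher numbers for weaker inhibition), compound 1 gives 25600 nM, the second highest of the three numbers. Compound 2 sits closest to it, within the scatter; compound 3 gives the lowest number, yet that gap too lies within the scatter, so none of the three can be ordered.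

Compound 4, `COc1cc(/C=N/Nc2nc(SCc3ccccc3)nc3c2nnn3Cc2ccccc2)cc(OC)c1OC`, has not been measured. It differs from compound 1 by phenyl in place of ethynyl on a saturated chain carbon bound to a sulfur. Within the data shown here, no measured pair shows this change, and all three numbers cluster closely, so no step beyond the scatter is expected in either direction. Compound 4 is expected to give about 20000 nM, between 8000 nM and 50000 nM, a step of a 1.3-fold lower number from compound 1 to compound 4 (0.11 log units; within the scatter) that is estimated to stay within the scatter.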

Compound 4, half-maximal inhibitory concentration: 48300 nM
Estimate against measurement, compound 4: 2.4-fold (0.38 log units) below, and the stated range covers the measured number.
By their numbers in this assay, from the lowest: compounds 3, 1, 2 and 4 (each within the scatter of the next, the first and the last beyond it).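

Among these compounds, compound 1 and compound 4 form the first pair here that differs in one place, on a saturated chain carbon bound to a sulfur. In this assay, propargyl to benzyl gives a 1.9-fold higher number from compound 1 to compound 4 (0.28 log units; within the scatter), so this exchange of ethynyl for phenyl, with its six-membered aromatic ring, stays within the scatter. Nothing measured here bears on the reason for this result. Open, going by these compounds, is whether an amine, a carboxylic acid or a longer chain in this place would give a step beyond the scatter, and whether propargyl to benzyl gives a similar step on compounds with another hydrazone part.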